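Aryl triazole oximes on a terpenoid ketone core: cytotoxicity

A few compounds are considered here, and "the series" means these few. Any claim that something is new, unique, unknown or untested is made for them only; others in the source may bear on it.

Compound 1 `CC(C)=CCC/C(C)=C/CC/C(C)=C/CC[C@@H]1[C@@]2(C)CCC(=O)C(C)(C)[C@@H]2CC[C@@]1(C)O` carries a ketone on the shared core; in a functional assay on HeLa cells (Homo sapiens) for cytotoxicity, read by MTT assay, with a stated time of 48 h (a higher number here means a weaker inhibitor, a lower number a stronger inhibitor), compound 1 gives 18300 nM. Compound 2 `CC(C)=CCC/C(C)=C/CC/C(C)=C/CC[C@@H]1[C@@]2(C)CC/C(=N\OCc3cn(-c4ccc(F)cc4)nn3)C(C)(C)[C@@H]2CC[C@@]1(C)O` replaces that ketone with an oxime ether bearing a 4-fluorophenyl triazole, and in this assay compound 2 gives 21400 nM, a value lying within the scatter of compound 1. Compound 3 `CC(C)=CCC/C(C)=C/CC/C(C)=C/CC[C@@H]1[C@@]2(C)CC/C(=N\OCc3cn(-c4cccc(C(F)(F)F)c4)nn3)C(C)(C)[C@@H]2CC[C@@]1(C)O` differs from compound 2 by 3-(trifluoromethyl)phenyl in place of 4-fluorophenyl on an aromatic nitrogen. Among the measured compounds shown here, no measured pair shows what this change does; given the near-equal values of compound 1 and compound 2, no step beyond the scatter is expected, a 1.1-fold lower number from compound 2 to compound 3 (0.03 log units; within the scatter). Compound 3 is estimated at 20000 nM, within 8000 nM to 50000 nM.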

Compound 3, half-maximal inhibitory concentration: 12500 nM
Estimate against measurement, compound 3: 1.6-fold (0.20 log units) above, within the range that was stated.
By their numbers in this assay, from the lowest: compounds 3, 1 and 2 (each within the scatter of the next).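

In this assay, 3-(trifluoromethyl)phenyl in place of 4-fluorophenyl on the aromatic nitrogen gives a 1.7-fold lower number from compound 2 to compound 3 (0.23 log units; within the scatter). Among the compounds shown here, this is the first step read at this position, and it shows that this exchange of one aryl group for another, with more heavy atoms, stays inside the scatter. Nothing at hand speaks to a cause for this step.

The groups shown at this position are both substituted phenyl rings. Open, on these data alone, is whether a longer alkyl chain, an amine or a carboxylic acid on that aromatic nitrogen would give a step beyond the scatter.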